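The compounds below may be only part of what the source reports. "The series", "measured", "known", "first", "only" and "open" are said of these compounds alone.

Three compounds share one core and differ only in the group on the six-membered aromatic ring with two nitrogens. Compound 1 `N#Cc1ncncc1-c1nc2cc(F)c(F)cc2n1C1CC1` carries a cyano there and in an ADME assay on cells for inhibition of cytochrome P450 11B1, mitochondrial (Homo sapiens), read by HPLC, with a stated time of 60 min (on this read-out lower numbers stand for stronger inhibition and higher numbers for weaker inhibition), compound 1 gives 4990 nM. Compound 2 `CNc1ncncc1-c1nc2cc(F)c(F)cc2n1C1CC1` carries a methylamino, and in this assay compound 2 gives 390 nM. Compound 3 `Fc1cc2nc(-c3cncnc3NCCC(F)(F)F)n(C3CC3)c2cc1F` carries a (3,3,3-trifluoropropyl)amino, and in this assay compound 3 gives 378 nM, the lowest number of the three, though its gap to compound 2 lies within the scatter.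

Compound 4 `CC(F)(F)c1ncncc1-c1nc2cc(F)c(F)cc2n1C1CC1` changes this position again: 1,1-difluoroethyl in place of (3,3,3-trifluoropropyl)amino on an aromatic carbon. Two measured steps speak to it. Replacing the cyano by an amino group gave a 13-fold lower number from compound 1 to compound 2 (1.11 log units; beyond the scatter) and a 13-fold lower number from compound 1 to compound 3 (1.12 log units; beyond the scatter), both large drops, while lengthening the chain on the nitrogen gave a 1.0-fold lower number from compound 2 to compound 3 (0.01 log units; within the scatter), no change beyond the scatter. Going by the values given here, no measured step shows what happens when the nitrogen itself is removed and a 1,1-difluoroethyl takes its place, so the forecast is uncertain. Because compound 1 without an amino group gives 4990 nM, compound 4 is expected to land between the amino compounds and the cyano compound, a step of a 4.0-fold higher number from compound 3 to compound 4 (0.60 log units; beyond the scatter). Compound 4 is estimated at 1500 nM, within 400 nM to 5500 nM.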

Compound 4, half-maximal inhibitory concentration: 5720 nM
The estimate for compound 4 lay 3.8-fold (0.58 log units) below the measured number; measured number above the stated range.
By their numbers in this assay, from the lowest: compounds 3 and 2 (each within the scatter of the next); then compounds 1 and 4 (each within the scatter of the next).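

In this assay, putting 1,1-difluoroethyl in place of the amino groups gives a 15-fold higher number from compound 3 to compound 4 (1.18 log units; beyond the scatter) and a 15-fold higher number from compound 2 to compound 4 (1.17 log units; beyond the scatter), so among these four compounds the low numbers belong only to the two with a nitrogen joining the substituent to the aromatic ring, and no compound shown goes against this. Compared with the cyano group, the same group gives a 1.1-fold higher number from compound 1 to compound 4 (0.06 log units; within the scatter), which means that compound 1 and compound 4, both joined through carbon, cannot be told apart here despite carrying quite different groups. No measurement here explains this link between the joining atom and the number.

The compounds shown leave open whether the nitrogen alone is enough or its hydrogen also counts: a dimethylamino group would keep the nitrogen without that hydrogen, while a methoxy group would put an oxygen in its place. Going by these compounds alone, they also leave open how much the group on the nitrogen can vary, since methylamino and (3,3,3-trifluoropropyl)amino are the only two examples, and neither a plain amine nor a ring such as morpholine appears among them.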